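Notes on replacing the hydroxy group of compound 2

This account rests on a few compounds, and the source may have more. Where it says the series, first, only, none or still open, it means among the compounds named here.

Compound 1 `COc1c(N2C[C@H]3CCCN(C(=O)Cn4cc(CN5C(=O)/C(=N/O)c6ccccc65)nn4)[C@H]3C2)c(F)cc2c(=O)c(C(=O)O)cn(C3CC3)c12`: 32 ug/mL
Compound 2 `COc1c(N2C[C@H]3CCCN(C(=O)Cn4cc(CN5C(=O)/C(=N/O)c6cccc(F)c65)nn4)[C@H]3C2)c(F)cc2c(=O)c(C(=O)O)cn(C3CC3)c12`: 16 ug/mL
Compound 3 `COc1c(N2C[C@H]3CCCN(C(=O)Cn4cc(CN5C(=O)/C(=N/NC(N)=S)c6cccc(F)c65)nn4)[C@H]3C2)c(F)cc2c(=O)c(C(=O)O)cn(C3CC3)c12`: not yet measured

Among the measured compounds shown here, in an ADME assay on Vero cells (Chlorocebus sabaeus) for cytotoxicity, read by MTT assay, with a stated time of 72 h (a higher number here means that more compound is tolerated, a lower number that less compound is tolerated), only two compounds have numbers, and compound 2 at 16 ug/mL lies within the scatter of compound 1, so the pair cannot be ranked.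

The move to compound 3 is a group of 4 heavy atoms (1 carbon, 2 nitrogen, 1 sulfur; no ring) in place of one oxygen atom, on a double-bonded nitrogen: hydroxy leaves, and a group of 4 heavy atoms (1 carbon, 2 nitrogen, 1 sulfur; no ring) enters in place of one oxygen atom, on a double-bonded nitrogen.

For the measured compounds named here, the only measured step, a 2.0-fold lower number from compound 1 to compound 2 (0.30 log units; within the scatter), is a fluoro in place of hydrogen on an aromatic carbon. Going by the values given here, it is small, but it is a different change, and no measured step involves this double-bonded nitrogen. The series therefore offers only weak guidance here. No step beyond the scatter is expected in this assay, with a slight lean to a lower number that rests on judgement alone. The expected change is a 1.3-fold lower number from compound 2 to compound 3 (0.12 log units; within the scatter) as an estimate. For compound 3 the estimated value is 12 ug/mL, with an expected range from 4 ug/mL to 32 ug/mL as a deliberately wide span.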

Compound 3, half-maximal cytotoxic concentration: 8 ug/mL
Compound 3: the middle estimate sits 1.5-fold (0.18 log units) above what was measured, and the stated range covers the measured number.
By their numbers in this assay, from the lowest: compounds 3, 2 and 1 (each within the scatter of the next, the first and the last beyond it).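

In this assay, the double-bonded nitrogen now has its first measured step: a 2.0-fold lower number from compound 2 to compound 3 (0.30 log units; within the scatter), with hydroxy replaced by a group of 4 heavy atoms (1 carbon, 2 nitrogen, 1 sulfur; no ring). Compounds 1 and 2 both carry hydroxy at this place, so they could not show whether it accepts anything else; compound 3 shows that this exchange, with its 2 hydrogen-bond donors in the entering group against 1 in the hydroxy, leaves the reading within the scatter of compound 2. No measurement on hand accounts for this result, and the reading stands as an observation only.

On these data alone, with a single exchange at this place, it remains open whether the outcome is peculiar to this sulfur-bearing group or would also hold for a methoxy group, an amine or a longer carbon chain on the double-bonded nitrogen. As far as these compounds go, it is also open whether the same exchange would read alike without the fluoro group, as compounds 2 and 3 both carry it and so cannot separate the two changes.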